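Removing the tert-Butyl Group from the Benzamide Ring

The compounds below may be only part of what the source reports. "The series", "measured", "known", "first", "only" and "open" are said of these compounds alone.

Among the compounds with values here, compound 3 `CCOC(=O)c1sc(-c2cccc(NC(=O)c3ccc(C(C)(C)C)cc3)c2)nc1Nc1ccc(N2CCN(C)CC2)cc1` stands lowest of the three compounds so far measured in a functional assay on Raji cells (Homo sapiens) for antiproliferative activity, read by CCK-8 assay, with a stated time of 72 h, tested at 40 uM; a higher number here means more inhibition at the concentration tested (going by the name of the read-out), a lower number less inhibition: compound 3 gives 4.22%, whereas compound 2 `CCOC(=O)c1sc(-c2cccc(NC(=O)c3ccc(F)cc3)c2)nc1Nc1ccc(N2CCN(C)CC2)cc1` gives 16.8% and compound 1 `CCOC(=O)c1sc(-c2cccc(NC(=O)c3ccc(C(F)(F)F)cc3)c2)nc1Nc1ccc(N2CCN(C)CC2)cc1` gives 33%, and both gaps lie beyond the scatter. Compound 4 `CCOC(=O)c1sc(-c2cccc(NC(=O)c3ccccc3)c2)nc1Nc1ccc(N2CCN(C)CC2)cc1` differs from compound 3 in one place: hydrogen in place of tert-butyl on an aromatic carbon. Within the data shown here, two measured steps bear directly on this change, since both introduced the tert-butyl group onto the same aromatic carbon: a number 28.8 percentage points lower from compound 1 to compound 3 (beyond the scatter) and a number 12.6 percentage points lower from compound 2 to compound 3 (beyond the scatter). In each of them, tert-butyl arriving in place of a smaller group lowered the number by a modest amount beyond the scatter. Taking tert-butyl away again in favour of hydrogen is therefore expected to move the number upward, by a modest step estimated at a number 9.8 percentage points higher from compound 3 to compound 4 (within the scatter) in this assay. Compound 4 is accordingly expected to give about 14% in this assay, within a range from 3% to 28%.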

Compound 4, a percentage reported as inhibition, at one concentration (the size of the read-out at that concentration, not a potency): 42%
Compound 4: the middle estimate sits 28 percentage points below what was measured; measured number above the stated range.
By their numbers in this assay, from the lowest: compound 3; then compound 2; then compounds 1 and 4 (each within the scatter of the next).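

In this assay, within the data shown here, the step of a number 37.8 percentage points higher from compound 3 to compound 4 (beyond the scatter) on loss of tert-butyl and the step of a number 25.2 percentage points higher from compound 2 to compound 4 (beyond the scatter) on loss of fluoro place both groups below hydrogen at this aromatic carbon, a comparison the earlier compounds, all substituted there, could not offer. Trifluoromethyl is not separated from hydrogen, with a number 9 percentage points higher from compound 1 to compound 4 (within the scatter) on that exchange, so none of the three groups shown gives a number clear of the unsubstituted benzoyl compound. Nothing available explains why the groups fall as they do.

As far as these compounds go, whether any group on this carbon can lift the number clear of hydrogen remains open, for instance an amine, a carboxylic acid or a methoxy group. Also open, from the compounds shown here alone, is whether the same group would read the same way on another carbon of this ring.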